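Two Aryl Ethers Measured, a Difluorophenyl Analogue to Come

The compounds below may be only part of what the source reports. "The series", "measured", "known", "first", "only" and "open" are said of these compounds alone.

Measured so far:
compound 1, `CC(C)[C@H](NC(=O)COc1cccc2ccccc12)C(=O)N[C@@H](CC(=O)O)C(=O)COc1ccc2ccccc2c1`: 15900 nM
compound 2, `CC(C)[C@H](NC(=O)COc1cccc2ccccc12)C(=O)N[C@@H](CC(=O)O)C(=O)COc1ccc(C#N)cc1`: 26700 nM

In a functional assay with Homo sapiens as the target (a higher number here means a weaker inhibitor, a lower number a stronger inhibitor), compound 2 gives the highest of the two numbers, and its nearest neighbour is compound 1, the two lying within the scatter of each other. The unmeasured compound 3, `CC(C)[C@H](NC(=O)COc1cccc2ccccc12)C(=O)N[C@@H](CC(=O)O)C(=O)COc1ccc(F)cc1F`, differs from compound 2 in one place: 2,4-difluorophenyl in place of 4-cyanophenyl on an oxygen on a saturated carbon. Going by the values given here, the one measured step that bears on an exchange of this aryl group, a 1.7-fold higher number from compound 1 to compound 2 (0.23 log units; within the scatter), stayed within the scatter. Compound 3 is therefore expected to give a number near that of compound 2, with the estimated step of a 1.2-fold lower number from compound 2 to compound 3 (0.08 log units; within the scatter). The estimate for compound 3 in this assay is 22000 nM, ranging from 8000 nM to 60000 nM.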

Compound 3, half-maximal inhibitory concentration: 17600 nM
The estimate for compound 3 lay 1.3-fold (0.10 log units) above the measured number; low and high end bracket the measured number.
By their numbers in this assay, from the lowest: compounds 1, 3 and 2 (each within the scatter of the next).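

Placing 2,4-difluorophenyl on the oxygen gives a 1.5-fold lower number from compound 2 to compound 3 (0.18 log units; within the scatter) and also a 1.1-fold higher number from compound 1 to compound 3 (0.04 log units; within the scatter) in this assay. The position thus accepts three different aryl groups, now including a fluorine-bearing ring with no nitrile, and all three compounds stay within the scatter of one another. Nothing available bears on the cause of this flat result. Still open, as far as these compounds go, is whether an amine, a carboxylic acid or a longer chain in place of the aryl group would move the number beyond the scatter.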